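From 4-nitrophenyl to 2-chloro-4-fluorophenyl

The compounds below may be only part of what the source reports. "The series", "measured", "known", "first", "only" and "open" are said of these compounds alone.

Compound 1 `O=C(N/N=C/c1ccc(F)cc1)Nc1cc2c(Nc3ccc(F)c(Cl)c3)ncnc2cc1O[C@H]1CCOC1`: 28200 nM
Compound 2 `O=C(N/N=C/c1cccc(Br)c1)Nc1cc2c(Nc3ccc(F)c(Cl)c3)ncnc2cc1O[C@H]1CCOC1`: 12400 nM
Compound 3 `O=C(N/N=C/c1ccc([N+](=O)[O-])cc1)Nc1cc2c(Nc3ccc(F)c(Cl)c3)ncnc2cc1O[C@H]1CCOC1`: "not active" (no number reported)

In a functional assay on MCF7 cells (Homo sapiens) for cytotoxicity, read by MTT assay, with a stated time of 72 h (a higher number here means a weaker inhibitor, a lower number a stronger inhibitor), compound 3 has no single number and is reported only as "not active" (no number reported). Compound 4 `O=C(N/N=C/c1ccc(F)cc1Cl)Nc1cc2c(Nc3ccc(F)c(Cl)c3)ncnc2cc1O[C@H]1CCOC1` departs from it by 2-chloro-4-fluorophenyl in place of 4-nitrophenyl on a carbon with a double bond to nitrogen, with 2-chloro-4-fluorophenyl in place of 4-nitrophenyl on a carbon with a double bond to nitrogen. Among the compounds with values here, no step from compound 3 can be sized. Within the data shown here, the one measured step, a 2.3-fold lower number from compound 1 to compound 2 (0.36 log units; beyond the scatter), is modest and concerns two other aryl groups. Compound 4 also carries a halogen-bearing phenyl, so a measurable value is expected, near compound 1 at 28200 nM and compound 2 at 12400 nM, rather than another report without a number. The estimated value for compound 4 is 17000 nM, with an expected range of 6000 nM to 45000 nM.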

Compound 4, half-maximal inhibitory concentration: 32200 nM
Beside the measured number, compound 4's estimate is 1.9-fold (0.28 log units) below it; the range from low to high includes it.
By their numbers in this assay, from the lowest: compound 2; then compounds 1 and 4 (each within the scatter of the next).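

In this assay chloro in place of hydrogen on an aromatic carbon makes no difference beyond the scatter, with a 1.1-fold higher number from compound 1 to compound 4 (0.06 log units; within the scatter), whereas 2-chloro-4-fluorophenyl in place of 3-bromophenyl gives a 2.6-fold higher number from compound 2 to compound 4 (0.41 log units; beyond the scatter), so the second halogen pattern tested here matters more than the added chloro. Within the data shown here, compound 3 has no number, so no step from it can be read, although a measurable value at this position now holds for three halogen-bearing phenyl groups. Nothing available explains these differences.

As far as these compounds go, what an aminophenyl or a carboxyphenyl group would give on this carbon stays open, as does whether any group here reaches far lower numbers.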